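The compounds below may be only part of what the source reports. "The series", "measured", "known", "first", "only" and "open" are said of these compounds alone.

Working notes on a hydroxamate series. Compound 1 `O=C(CCc1ccccc1)Nc1ccc2sc(C(=O)NO)cc2c1` carries a hydroxamic acid on the shared core with an amide-linked phenylpropanoyl arm; in a functional assay on HCT-116 cells (Homo sapiens) for cytotoxicity, read by resazurin assay, with a stated time of 5 days (on this read-out higher numbers stand for weaker inhibition and lower numbers for stronger inhibition), compound 1 gives "not determined" (no result reported), so no result is available for it. Going by the values given here, compound 2 `O=C(NCc1ccc2cc(C(=O)NO)sc2c1)c1cccnc1` is the only entry with a number: in this assay compound 2 gives 730 nM, so it stands alone and no comparison is available. Compound 3 `O=C(NCc1ccc2cc(C(=O)NO)sc2c1)c1ccccc1` differs from compound 2 by phenyl in place of pyridin-3-yl on a carbonyl carbon. Among the compounds with values here, with no measured step to lean on, the change is expected to move within the usual scatter, with no direction beyond it, giving an expected step of a 1.2-fold lower number from compound 2 to compound 3 (0.09 log units; within the scatter). Compound 3 is estimated at 600 nM, within 250 nM to 1500 nM.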

Compound 3, half-maximal inhibitory concentration: 250 nM
Estimate against measurement, compound 3: 2.4-fold (0.38 log units) above; the measured number falls inside the stated range.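

In this assay, going by these compounds alone, the swap of pyridin-3-yl for phenyl on a carbonyl carbon gives a 2.9-fold lower number from compound 2 to compound 3 (0.47 log units; beyond the scatter) and supplies the first measured step. This position therefore registers a change beyond the scatter even though the leaving and entering groups are both six-membered aromatic rings with 6 heavy atoms, one carrying a nitrogen and the other carbon only. No supporting data bear on the reason for the step.

Going by these compounds, whether a cyclohexyl ring, or a phenyl carrying a methoxy group or a chlorine, would extend this step remains open. Compound 1 has no number, so it adds nothing on the link or the arm.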